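This account rests on a few compounds, and the source may have more. Where it says the series, first, only, none or still open, it means among the compounds named here.

Series measured in a physicochemical assay, read by spectrophotometry, with a stated time of 30 min; on this read-out higher numbers stand for weaker inhibition and lower numbers for stronger inhibition
- compound 1 `O=C(CCc1nc2ccccc2c(=O)[nH]1)N/N=C/c1ccc(O)cc1` gives 238000000 nM
- compound 2 `COc1cc(/C=N/NC(=O)CCCc2nc3ccccc3c(=O)[nH]2)cc(OC)c1OC` gives 106000000 nM
- compound 3 `COc1cc(/C=N/NC(=O)CCCc2nc3ccccc3c(=O)[nH]2)ccc1O` gives 236000000 nM

Compound 3 stands level with compound 1 within the scatter, while compound 2 gives a lower number, beyond the scatter of both. The next compound to be read is compound 4 `COc1cc(/C=N/NC(=O)CCCc2nc3ccccc3c(=O)[nH]2)cc(O)c1O` with hydroxy in place of hydrogen on an aromatic carbon of compound 3, ortho to a hydroxy group and meta to a methoxy group, counted as hydroxy in place of hydrogen on an aromatic carbon for this change.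

Among the measured compounds shown here, no two measured compounds differ in one place, so no measured step isolates this change and the expectation rests on thin evidence. Compound 2 at 106000000 nM shows that numbers lower than that of compound 3 occur in this small set. In this assay a lower number beyond the scatter is expected, and the estimated move is a 3.9-fold lower number from compound 3 to compound 4 (0.59 log units; beyond the scatter) with wide uncertainty. For compound 4 the estimated value is 60000000 nM within an expected range of 15000000 nM to 180000000 nM as the working figure.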

Compound 4, half-maximal inhibitory concentration: 88000000 nM
For compound 4 the middle estimate is 1.5-fold (0.17 log units) below the measured one, and the stated range covers the measured number.
By their numbers in this assay, from the lowest: compounds 4 and 2 (each within the scatter of the next); then compounds 3 and 1 (each within the scatter of the next).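

Hydroxy in place of hydrogen on an aromatic carbon, ortho to a hydroxy group and meta to a methoxy group, gives in this assay the first single-place step in the series: a 2.7-fold lower number from compound 3 to compound 4 (0.43 log units; beyond the scatter). This shows that the change at this position can move the read-out beyond the scatter, towards stronger inhibition, although the finding rests on this one pair. No measurement shown here accounts for the step.

Going by these compounds, whether an amine or a carboxylic acid at the same position would move the number in the same direction, or by a similar amount, remains open. Also open, on these data alone, is whether the added hydroxy would give a comparable step on the aromatic ring of compound 1, which carries no methoxy group.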